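A few compounds are considered here, and "the series" means these few. Any claim that something is new, unique, unknown or untested is made for them only; others in the source may bear on it.

Among the compounds with values here, compound 2 `Oc1cccc(-c2cc(-c3ccccc3OC(F)(F)F)cc(-c3ccccc3O)n2)c1` gives the only full number here: in a functional assay on T47D cells (Homo sapiens) for inhibition (on this read-out higher numbers stand for weaker inhibition and lower numbers for stronger inhibition), compound 2 gives 2680 nM. Compound 1 `Oc1ccc(-c2cc(-c3ccccc3F)cc(-c3ccccc3O)n2)cc1` sits at the limit of > 50000 nM in this assay, at which 1 of the 2 values shown sits, which is a limit of the assay rather than a number; in this assay compound 1 gives > 50000 nM. Compound 3 `Oc1ccc(-c2cc(-c3ccccc3OC(F)(F)F)cc(-c3ccccc3O)n2)cc1` carries 4-hydroxyphenyl in place of 3-hydroxyphenyl on an aromatic carbon, the 4-hydroxyphenyl that compound 1 also bears. Compound 3 is expected to be weaker than compound 2, with a step of a 3.7-fold higher number from compound 2 to compound 3 (0.57 log units; beyond the scatter) beyond the usual scatter. In this assay compound 3 is estimated at 10000 nM, between 3000 nM and 50000 nM.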

Compound 3, half-maximal inhibitory concentration: 2050 nM
Estimate against measurement, compound 3: 4.9-fold (0.69 log units) above; measured number outside the range, below it.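

In this assay, 4-hydroxyphenyl in place of 3-hydroxyphenyl next to the ring nitrogen gives a 1.3-fold lower number from compound 2 to compound 3 (0.12 log units; within the scatter), so this change leaves the read-out within the scatter. The large difference lies at the other place, where trifluoromethoxy in place of fluoro gives an at least 24-fold lower number from compound 1 to compound 3 (1.38 log units; beyond the scatter). Compound 1 stands at a limit of the assay, not at a number: the limit of > 50000 nM in this assay, at which 1 of the 3 values shown sits.

From the compounds shown here alone, whether an aminophenyl or a carboxyphenyl at this position would give a similar value stays open. So does how 3-hydroxyphenyl would read alongside fluoro instead of trifluoromethoxy.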